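The compounds below may be only part of what the source reports. "The series", "measured", "known", "first", "only" and "open" are said of these compounds alone.

In a functional assay on DU-145 cells (Homo sapiens) for cytotoxicity, read by sulforhodamine B assay, with a stated time of 48 h (on this read-out lower numbers stand for stronger inhibition of growth and higher numbers for weaker inhibition of growth), compound 1 `N#Cc1ccc(Nc2nc(Oc3ccnc4ccccc34)nc(N3CCN(c4ccccc4Cl)CC3)n2)cc1C(F)(F)F` gives 92600 nM, the higher of the two numbers that were obtained. Compound 2 `CC1CC(C)CN(c2nc(Nc3ccc(C#N)c(C(F)(F)F)c3)nc(Oc3ccnc4ccccc34)n2)C1` gives 27200 nM in this assay, a difference from compound 1 that goes beyond the usual scatter. Compound 3 `N#Cc1ccc(Nc2nc(Oc3ccnc4ccccc34)nc(N3CCN(Cc4ccccc4)CC3)n2)cc1C(F)(F)F` reaches only the limit of this assay, giving > 100000 nM; that is a limit, not a number. Among the compounds with values here, the one measured step starting from compound 1, an at least 1.0-fold higher number from compound 1 to compound 3 (0.03 log units; that floor lies within the scatter), can therefore be read only through (the limit of > 100000 nM in this assay, at which 1 of the 3 values shown sits), and it sets no clear size for the change.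

Compound 4 `N#Cc1ccc(Nc2nc(Oc3ccnc4ccccc34)nc(N3CCN(c4ccccc4)CC3)n2)cc1C(F)(F)F` differs from compound 1 by hydrogen in place of chloro on an aromatic carbon, a smaller change than the swap to benzyl in compound 3, since the phenyl ring on the amine nitrogen in the ring is kept. Within the data shown here, no measured pair separates only the chloro from the hydrogen on that ring, so there is no step that bears directly on this change. With compound 1 already standing close to the limit of this assay, compound 4 is expected to show no step beyond the scatter, a 1.0-fold higher number from compound 1 to compound 4 (0.01 log units; within the scatter), and it may itself end at the limit. Compound 4 is estimated at 95000 nM in this assay, within a range from 40000 nM to 200000 nM.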

Compound 4, concentration for 50% growth inhibition: > 100000 nM
Compound 4: only a limit was reported; the forecaster's own chance of this, stated with the estimate: 45%; middle value at least 1.0-fold (0.02 log units) away from the limit.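

In this assay compound 4 gives > 100000 nM, which is a limit of the assay and not a number. Taking the chloro off the aromatic carbon gives an at least 1.0-fold higher number from compound 1 to compound 4 (0.03 log units; that floor lies within the scatter), so the change from 2-chlorophenyl to phenyl does not lower the number, but its true size stays unknown, and the chloro cannot be said to matter or not to matter on this evidence. Within the data shown here, the clearer new finding concerns the group on the shared core as a whole: the 4-phenylpiperazin-1-yl group in place of 3,5-dimethylpiperidin-1-yl gives an at least 3.6-fold higher number from compound 2 to compound 4 (0.56 log units; beyond the scatter), the first step in this set with a floor that lies beyond the scatter.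

Going by these compounds, how far compound 3 and compound 4 lie from each other stays open, and the step between them cannot be read because both stand at the limit: the limit of > 100000 nM in this assay, at which 2 of the 4 values shown sit. Also open is whether a fluoro, a methoxy or an amine on that aromatic carbon, in place of the chloro, would give a number clearly below that limit.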